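Swapping a Saturated Ring for an Aryl Amide

The source may hold more compounds than are shown below. What is called first, only, known or untested is meant among the compounds shown, and "the series" means these compounds.

Compound 1 `O=C(C1CCCCC1)N1CC(c2nc(-c3cccc(F)c3)no2)C1` carries a cyclohexyl amide on the shared core. In an assay on HEK293 cells for negative allosteric modulation of metabotropic glutamate receptor 5 (Homo sapiens), read by FLIPR (a lower number here means a stronger inhibitor, a higher number a weaker inhibitor), compound 1 gives only a limit, > 10000 nM. Compound 3 `O=C(C1CCC(C(F)(F)F)CC1)N1CC(c2nc(-c3cccc(F)c3)no2)C1`, which adds a trifluoromethyl group, likewise gives only a limit in this assay, > 10000 nM. The step that the two limits leave unreadable from compound 1 to compound 3 cannot be read, since both values sit at the limit of > 10000 nM in this assay, at which 2 of the 3 values shown sit. Going by the values given here, compound 2 `Cc1ccc(S(=O)(=O)N2CC(c3nc(-c4cccc(Cl)c4)no3)C2)cc1`, a sulfonamide bearing a chloro group, gives 920 nM in this assay and is the only compound here with a number. Compound 4 `O=C(c1ccc(F)cc1)N1CC(c2nc(-c3cccc(F)c3)no2)C1` differs from compound 1 by 4-fluorophenyl in place of cyclohexyl on a carbonyl carbon. Among the compounds with values here, no measured step covers this kind of change, so its direction is unknown. Compound 4 is estimated at 3000 nM, within 500 nM to 10000 nM, an expected step of an at least 3.3-fold lower number from compound 1 to compound 4 (0.52 log units; beyond the scatter) of uncertain size.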

Compound 4, half-maximal inhibitory concentration: > 10000 nM
Compound 4 was reported as a limit; the forecaster's own chance of this, stated with the estimate: 40%; at least 3.3-fold (0.52 log units) between middle value and limit.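

Compound 1 and compound 4 both give only a limit, so no step can be read between them: the limit of > 10000 nM in this assay, at which 3 of the 4 values shown sit.

Going by these compounds, whether 4-fluorophenyl in place of cyclohexyl changes inhibition at all, and in which direction, stays open.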